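Swapping the amide group: from compound 2 to compound 4

The source may report more compounds than this note shows. Statements on the series, on what has been measured and on what is new or still open speak of the compounds shown alone.

Measured in a functional assay on MDA-MB-435 cells (Homo sapiens) for cytotoxicity, read by MTT assay, with a stated time of 72 h; a lower number here means a stronger inhibitor, a higher number a weaker inhibitor:
- Compound 1 `CN(C)c1ccc(CNC(=O)c2nc(Br)c3cccnc3c2N[C@H]2CC[C@H](N)CC2)cc1`: 4000 nM
- Compound 2 `C[C@H](NC(=O)c1nc(Br)c2cccnc2c1N[C@H]1CC[C@H](N)CC1)c1ccc(F)cc1`: > 10000 nM, a limit
- Compound 3 `Cc1ccc(S(=O)(=O)Oc2c(C(=O)NCc3ccc(F)cc3)nc(Br)c3cccnc23)cc1`: > 20000 nM, a limit

Among these results, compound 1 alone has a true number, 4000 nM. Compound 2 stands at a limit, > 10000 nM, and not at a number. Compound 3 also gives only a limit, > 20000 nM. It differs from the other two in more than one place, so it offers no clean comparison.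

Compound 4 `N[C@H]1CC[C@H](Nc2c(C(=O)NCc3ccccc3)nc(Br)c3cccnc23)CC1` is the next to be tested in this assay. The change is benzyl in place of 1-(4-fluorophenyl)ethyl on an amide-type nitrogen.

Going by the values given here, one measured step bears on this: an at least 2.5-fold higher number from compound 1 to compound 2 (0.39 log units; beyond the scatter). It lies beyond the scatter and shows that the group on this nitrogen can matter. Compound 4 carries a benzyl group, as compound 1 does in its substituted form, so a modest move towards a lower number is expected. The expected step is an at least 1.6-fold lower number from compound 2 to compound 4 (0.22 log units; that floor lies within the scatter). For compound 4 the estimated value is 6000 nM, with an expected range from 2000 nM to 18000 nM.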

Compound 4, half-maximal inhibitory concentration: 7000 nM
Beside the measured number, compound 4's estimate is 1.2-fold (0.07 log units) below it, and the stated range covers the measured number.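

In this assay, the new result separates two questions about the group on the amide-type nitrogen. The step of a 1.8-fold higher number from compound 1 to compound 4 (0.24 log units; within the scatter) means that compound 1 and compound 4 cannot be told apart, so hydrogen in place of dimethylamino on an aromatic carbon has no shown effect on the number. The other step, an at least 1.4-fold lower number from compound 2 to compound 4 (0.15 log units; that floor lies within the scatter), gives only a floor for benzyl in place of 1-(4-fluorophenyl)ethyl because compound 2 has a limit and not a true number: the limit of > 10000 nM in this assay, at which 1 of the 4 values shown sits.

The compounds shown leave open whether the fluorine or the extra carbon of 1-(4-fluorophenyl)ethyl matters more. They also leave open whether an amine or a carboxylic acid on the aromatic ring, or a longer chain in place of benzyl, would move the number beyond the scatter.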